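Chloro on the aromatic ring of compound 3: working notes

This account rests on a few compounds, and the source may have more. Where it says the series, first, only, none or still open, it means among the compounds named here.

These notes follow growth inhibition in a functional assay on HO8910 cells (Homo sapiens) for inhibition, read by MTT assay, with a stated time of 24 h, tested at 100 ug/mL; on this read-out lower numbers stand for less inhibition of growth and higher numbers for more inhibition of growth at the one concentration tested. Compound 1 `O=C(CCCCC1CCSS1)Nc1ccccc1Cl` is reported only as "not active" (no number reported), without a number. Compound 2 `O=C(CCCCC1CCSS1)Nc1ccc(Cl)cn1` gives 68.6%. Compound 3 `CC(=O)SCCC(CCCCC(=O)Nc1ccccc1)SC(C)=O` gives 22.3%, the lower of the two numbers available and beyond the scatter from that of compound 2.

Compound 4 `CC(=O)SCCC(CCCCC(=O)Nc1ccc(Cl)cc1)SC(C)=O` differs from compound 3 in one place: chloro in place of hydrogen on an aromatic carbon, para to a large group. Going by the values given here, no measured pair isolates this change. Compound 1 and compound 2 both carry chloro, but on a core different from that of compound 3, and their results diverge, so they give no clear direction. The starting point for the expectation is therefore compound 3 at 22.3%. A small upward step, within the scatter, is expected in this assay: a number 7.7 percentage points higher from compound 3 to compound 4 (within the scatter). The estimated value for compound 4 is 30%, with an expected range of 8% to 60%.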

Compound 4, percent growth inhibition at one concentration: 58.8%
Compound 4: middle estimate off by 28.8 percentage points, on the low side, within the range that was stated.
By their numbers in this assay, from the lowest: compound 3; then compounds 4 and 2 (each within the scatter of the next).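

In this assay, chloro in place of hydrogen on an aromatic carbon, para to a large group, gives a number 36.5 percentage points higher from compound 3 to compound 4 (beyond the scatter) on the shared core. This position therefore responds clearly to a change of one heavy atom, which compounds 1 and 2 could not show: they differ from compound 3 in more than one place. Going by these compounds alone, this is the only one-place comparison so far, and nothing measured bears on why the step arises.

On these data alone, it remains open whether the step is specific to chloro or would also appear with fluoro, methoxy or a carboxylic acid on the same carbon. As far as these compounds go, it is also open whether chloro on another carbon of the ring would give a comparable step, and whether the step would hold at concentrations other than the one tested.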